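This account rests on a few compounds, and the source may have more. Where it says the series, first, only, none or still open, it means among the compounds named here.

Compound 1 `CCCCCCOc1ccc(-n2cnnc2CCCCCC)cc1` — in a functional assay on the whole organism (strain C57B/6) with Mus musculus as the target, in the maximal electroshock model (on this read-out higher numbers stand for an effect only at larger amounts of compound and lower numbers for an effect already at smaller amounts), compound 1 gives > 40 mg/kg, which is a limit of the assay rather than a number.
Compound 2 `CCCCCCOc1ccc(-n2cnnc2-c2ccccc2)cc1` — compound 2 gives 19 mg/kg.
Compound 3 `CCCCCCOc1ccc(-n2cnnc2-c2ccc(F)cc2)cc1` — compound 3 gives 22 mg/kg.

Among the two plain numbers, compound 3 has the highest one, with compound 2 nearest; the step of a 1.2-fold higher number from compound 2 to compound 3 (0.06 log units; within the scatter) lies within the scatter. The steps of an at least 2.1-fold lower number from compound 1 to compound 2 (0.32 log units; beyond the scatter) and an at least 1.8-fold lower number from compound 1 to compound 3 (0.25 log units; that floor lies within the scatter) swap the whole side group on the core and start from a limit, so they say little about a small change on the phenyl ring.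

Compound 4 `CCCCCCOc1ccc(-n2cnnc2-c2ccc(OC)cc2)cc1` differs from compound 3 only in this: methoxy in place of fluoro on an aromatic carbon. Within the data shown here, no measured step swaps these two groups; the only step at that place is the small one from compound 2 to compound 3. The step of no change at the digits printed from compound 3 to compound 4 (within the scatter) is therefore expected to stay within the scatter. Compound 4 is estimated to give 22 mg/kg, between 10 mg/kg and 45 mg/kg.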

Compound 4, dose for half-maximal effect: 15.8 mg/kg
The estimate for compound 4 lay 1.4-fold (0.14 log units) above the measured number; low and high end bracket the measured number.
By their numbers in this assay, from the lowest: compounds 4, 2 and 3 (each within the scatter of the next). At a limit, above all of these: compound 1.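

At this place on the phenyl ring, methoxy cannot be told apart from fluoro or hydrogen in this assay: the steps, a 1.4-fold lower number from compound 3 to compound 4 (0.14 log units; within the scatter) and a 1.2-fold lower number from compound 2 to compound 4 (0.08 log units; within the scatter), are both small. So a group with one more heavy atom and a hydrogen-bond acceptor still leaves the number within the scatter. The 4-methoxyphenyl group also gives an at least 2.5-fold lower number from compound 1 to compound 4 (0.40 log units; beyond the scatter), a step that starts from a limit: the limit of > 40 mg/kg in this assay, at which 1 of the 4 values shown sits.

Going by these compounds, whether an amine or a carboxylic acid at this place would move the number beyond the scatter stays open.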